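Arylpiperazine variation at the ring nitrogen: predicted dichlorophenyl analogue

The source may hold more compounds than are shown below. What is called first, only, known or untested is meant among the compounds shown, and "the series" means these compounds.

Compound 1 `Nc1scc(CN2CCN(c3cccc(C(F)(F)F)c3)CC2)c1C(=O)c1ccc(Cl)cc1` gives -80% in a functional assay on CHO cells with adenosine receptor A1 (Homo sapiens) as the target, read by cAMP accumulation and immunoassay, with a stated time of 6 min, tested at 10 uM; on this read-out lower numbers stand for a stronger effect and higher numbers for a weaker effect at the one concentration tested. Compound 3 `Nc1scc(CN2CCN(c3c(F)cc(F)cc3F)CC2)c1C(=O)c1ccc(Cl)cc1` gives -78%, and compound 2 `Nc1scc(CN2CCN(c3ccncc3)CC2)c1C(=O)c1ccc(Cl)cc1` gives -15%. Compound 1 has the lowest number of the three: its step to compound 3 is a number 2 percentage points higher from compound 1 to compound 3 (within the scatter), whereas its step to compound 2 is a number 65 percentage points higher from compound 1 to compound 2 (beyond the scatter). The reverse comparison, a number 63 percentage points lower from compound 2 to compound 3 (beyond the scatter), shows the same split: a six-membered aromatic ring of carbon only on the amine nitrogen in the ring, whether 3-(trifluoromethyl)phenyl or 2,4,6-trifluorophenyl, sits at the strong end, while pyridin-4-yl sits at the weak end.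

Compound 4 `Nc1scc(CN2CCN(c3ccc(Cl)c(Cl)c3)CC2)c1C(=O)c1ccc(Cl)cc1` differs from compound 1 only at that position: 3,4-dichlorophenyl in place of 3-(trifluoromethyl)phenyl on an amine nitrogen in a ring. For the measured compounds named here, the change keeps a six-membered aromatic ring of carbon only, so the step that bears on it is the one from compound 1 to compound 3, which stayed within the scatter, rather than the large step from compound 1 to compound 2. No step beyond the scatter is therefore expected in this assay; the estimated change is a number 4 percentage points higher from compound 1 to compound 4 (within the scatter). Compound 4 is estimated at -76%, with a range from -92% to -52%.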

Compound 4, a percentage reported as activity, at one concentration (the size of the read-out at that concentration, not a potency): -62%
Compound 4: middle estimate off by 14 percentage points, on the low side; low and high end bracket the measured number.
By their numbers in this assay, from the lowest: compounds 1 and 3 (each within the scatter of the next); then compound 4; then compound 2.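

In this assay, a six-membered aromatic ring of carbon only on the amine nitrogen in the ring no longer guarantees a place at the strong end: there is a number 18 percentage points higher from compound 1 to compound 4 (beyond the scatter) and likewise a number 16 percentage points higher from compound 3 to compound 4 (beyond the scatter), both modest. The groups on that ring can therefore shift the read-out, although the different groups of compound 1 and compound 3 gave no such separation. Compound 4 nevertheless stays well clear of the pyridin-4-yl analogue, with a number 47 percentage points lower from compound 2 to compound 4 (beyond the scatter), so 3,4-dichlorophenyl takes an intermediate place and the large loss remains specific, among these compounds, to pyridin-4-yl. Nothing available accounts for the gap between 3,4-dichlorophenyl and the two groups at the strong end.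

The compounds shown leave open whether a phenyl ring bearing a single chlorine, a methoxy group or a nitrile would stay with compound 1 and compound 3 or fall back towards compound 4. They also leave open whether pyridin-3-yl or pyrimidin-2-yl would share the weak read-out of compound 2, or whether a benzyl group on the same nitrogen would keep the strong end.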